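This account rests on a few compounds, and the source may have more. Where it says the series, first, only, none or still open, it means among the compounds named here.

Compound 1 `CCN(CC)CCNC(=O)CC(CC(=O)N(C)C1Cc2ccccc2C1)c1ccccc1`: > 100000 nM (a limit of the assay, not a number)
Compound 2 `CCN(CC)CCNC(=O)CC(CC(=O)N(CC)C1Cc2ccccc2C1)c1ccc(Cl)cc1`: 44900 nM

The measurements come from a functional assay on MGC-803 cells (Homo sapiens) for inhibition; on this read-out higher numbers stand for weaker inhibition and lower numbers for stronger inhibition. In this assay, going by the values given here, compound 2 gives 44900 nM, the only actual number so far. Compound 3 `CCN(CC)CCNC(=O)CC(CC(=O)N(C)C1Cc2ccccc2C1)c1ccc(Cl)cc1` differs from compound 2 in one place: hydrogen in place of methyl on a saturated chain carbon bound to an amide-type nitrogen. That is hydrogen in place of methyl on a saturated chain carbon bound to an amide-type nitrogen, which turns ethyl to methyl. Among the compounds with values here, no measured pair of compounds shows this change alone. The expected change is a 1.2-fold higher number from compound 2 to compound 3 (0.09 log units; within the scatter), small and probably within the usual scatter, with slightly weaker inhibition if anything. For compound 3 the estimate is 55000 nM, with an expected range of 22000 nM to 100000 nM.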

Compound 3, half-maximal inhibitory concentration: 81200 nM
Compound 3: middle estimate off by 1.5-fold (0.17 log units), on the low side, and the stated range covers the measured number.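

Swapping ethyl for methyl on the amide-type nitrogen gives a 1.8-fold higher number from compound 2 to compound 3 (0.26 log units; within the scatter), so this position shows no clear response to that change. Chloro in place of hydrogen on an aromatic carbon gives an at least 1.2-fold lower number from compound 1 to compound 3 (0.09 log units; that floor lies within the scatter), so this change also shows no clear effect, although its true size may be larger. The value of compound 1 is a limit of the assay, not a number: the limit of > 100000 nM in this assay, at which 1 of the 3 values shown sits.

On these data alone, whether a longer chain such as propyl on that nitrogen would shift the value beyond the scatter remains open. The same is true of fluoro or a carboxylic acid in place of the chloro.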